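The source may hold more compounds than are shown below. What is called first, only, known or untested is meant among the compounds shown, and "the series" means these compounds.

Compound 1 `CN1CCC=C(c2ccc(CN(C)Cc3ccc(Cl)cc3)cc2)C1` in a functional assay on HL-60 cells (Homo sapiens) for inhibition (on this read-out lower numbers stand for stronger inhibition and higher numbers for weaker inhibition), gives 2140 nM. Compound 2 `CN1CCC=C(c2ccc(CN(C)C/C=C/c3ccccc3)cc2)C1` gives 680 nM in this assay, and the change behind this, (2-phenylethenyl in place of 4-chlorophenyl on a saturated chain carbon bound to an amine nitrogen), made a 3.1-fold lower number from compound 1 to compound 2 (0.50 log units; beyond the scatter). Compound 3 `CN(Cc1ccc(Cl)cc1)Cc1ccc(C2CCCN(C)C2)cc1` carries a different core, described by a group of 7 heavy atoms (6 carbon, 1 nitrogen; one six-membered non-aromatic ring with 1 hetero atom) in place of a group of 7 heavy atoms (6 carbon, 1 nitrogen; one six-membered non-aromatic ring with 1 hetero atom), on an aromatic carbon, and in this assay compound 3 gives 1290 nM, a step of a 1.7-fold lower number from compound 1 to compound 3 (0.22 log units; within the scatter). Compound 4 `CN(C/C=C/c1ccccc1)Cc1ccc(C2CCCN(C)C2)cc1` is not yet measured; it is related to compound 3 by 2-phenylethenyl in place of 4-chlorophenyl on a saturated chain carbon bound to an amine nitrogen, the same change that led from compound 1 to compound 2, at the same place. Since the two cores are separated only by a step within the scatter, the step from compound 3 to compound 4 is expected to be a 2.9-fold lower number from compound 3 to compound 4 (0.46 log units; beyond the scatter), close to the earlier one. Compound 4 is therefore estimated at 450 nM in this assay, with a likely range from 200 nM to 1000 nM.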

Compound 4, half-maximal inhibitory concentration: 1100 nM
The estimate for compound 4 lay 2.4-fold (0.39 log units) below the measured number; the whole stated range lies below it.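

In this assay, 2-phenylethenyl in place of 4-chlorophenyl gave a step beyond the scatter on the core of compound 1, but on the core of compound 3 it gave a 1.2-fold lower number from compound 3 to compound 4 (0.07 log units; within the scatter), so the earlier step did not carry over at its size: the same change on two cores in this assay, a 3.1-fold lower number (0.50 log units; beyond the scatter) from compound 1 to compound 2 and a 1.2-fold lower number (0.07 log units; within the scatter) from compound 3 to compound 4, 2.7-fold (0.43 log units) apart, beyond the scatter of two such steps. Seen from the side of the cores, the exchange with 2-phenylethenyl present gave a 1.6-fold higher number from compound 2 to compound 4 (0.21 log units; within the scatter), which does not match the exchange with 4-chlorophenyl present: the same change on two cores in this assay, a 1.7-fold lower number (0.22 log units; within the scatter) from compound 1 to compound 3 and a 1.6-fold higher number (0.21 log units; within the scatter) from compound 2 to compound 4, 2.7-fold (0.43 log units) apart, beyond the scatter of two such steps. In these four compounds the group and the core therefore do not act independently, but the data do not show why, and one pair per core cannot show how general this is.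

As far as these compounds go, it remains open whether a 2-phenylethyl group or a 2-(4-chlorophenyl)ethenyl group at this place would follow compound 2 or compound 4. From the compounds shown here alone, it is also open whether the same gap between the cores would appear with these groups.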